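The source may report more compounds than this note shows. Statements on the series, on what has been measured and on what is new or still open speak of the compounds shown alone.

Going by the values given here, compound 2 `O=C(Nc1ccc(Sc2nc3ccccc3s2)cc1)c1ccccc1O` is one of three compounds measured in an assay on isolated protein for inhibition of thiosulfate sulfurtransferase (Homo sapiens), with a stated time of 60 min, in the absence of a further agent; a higher number here means a weaker inhibitor, a lower number a stronger inhibitor. In this assay compound 2 gives > 100000 nM, which is a limit of the assay rather than a number. Compound 1 `O=C(Nc1ccc(Sc2nc3ccccc3s2)c(Cl)c1)c1ccccc1O` carries a chloro on an aromatic carbon where compound 2 carries hydrogen. In this assay compound 1 gives > 100000 nM, again a limit. The step that the two limits leave unreadable from compound 1 to compound 2 is therefore not readable in size. Compound 3 `COc1ccccc1C(=O)Nc1cccc(Cl)c1` is built differently around the amide. In this assay compound 3 gives > 100000 nM, also a limit. Among the compounds with values here, all three measurements sit at the limit of > 100000 nM in this assay, at which 3 of the 3 values shown sit, so the numbers so far show no inhibition within the range the assay can report.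

Compound 4 `COc1c(Br)cccc1C(=O)Nc1ccc(Sc2nc3ccccc3s2)cc1` has not yet been measured. It differs from compound 2 by a group of 9 heavy atoms (7 carbon, 1 oxygen, 1 bromine; one six-membered aromatic ring of carbon only) in place of a group of 7 heavy atoms (6 carbon, 1 oxygen; one six-membered aromatic ring of carbon only), on a carbonyl carbon. Within the data shown here, no measured step bears directly on this change, and the one step that exists between the measured compounds is unreadable. Among the measured compounds shown here, since every value so far is a limit, compound 4 is expected to behave like the others and its step that the limit leaves unreadable from compound 2 to compound 4 is expected to be small or not measurable. Compound 4 is estimated at 150000 nM in this assay, within a range from 30000 nM to 1000000 nM.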

Compound 4, half-maximal inhibitory concentration: > 100000 nM
Compound 4 was reported as a limit; the forecaster's own chance of this, stated with the estimate: 80%; the middle value is on the limit's open side.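

Compound 2 and compound 4 are both reported only as limits in this assay, so the step between them cannot be read, and every compound shown stands the same way: the limit of > 100000 nM in this assay, at which 4 of the 4 values shown sit.

The compounds shown leave open whether any of these structures inhibits the enzyme measurably, and so which part of them would matter for inhibition.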